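Aryl urea variants on the shared core: compound 2 to compound 4

The compounds below may be only part of what the source reports. "The series", "measured", "known", "first", "only" and "open" are said of these compounds alone.

Notes on the series. Compound 1 `COc1cc(NC(C)CCCNC(=O)NNC(=O)Nc2cccc(F)c2)c2ncccc2c1` carries a 3-fluorophenyl on the terminal amide-type nitrogen; in a functional assay on SW-620 cells (Homo sapiens) for inhibition, read by MTT assay, with a stated time of 72 h (on this read-out lower numbers stand for stronger inhibition and higher numbers for weaker inhibition), compound 1 gives 9500 nM. Compound 2 `COc1cc(NC(C)CCCNC(=O)NNC(=O)Nc2ccc(O)cc2)c2ncccc2c1` has 4-hydroxyphenyl in that position. In this assay compound 2 reaches only a limit of the assay, > 100000 nM, so compound 2 sits at the weak end of the numbers shown, at the limit of > 100000 nM in this assay, at which 1 of the 3 values shown sits. Going by the values given here, the one single-point step measured so far, an at least 10-fold higher number from compound 1 to compound 2 (1.02 log units; beyond the scatter), is therefore large. Compound 3 `COc1cc(NC(C)CCCNC(=O)Nc2cc(C(F)(F)F)cc(C(F)(F)F)c2)c2ncccc2c1` is a plain aryl urea on the same core and in this assay compound 3 gives 3900 nM; it differs from compound 1 in more than one place, so only the two values themselves are compared.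

Compound 4 `COc1cc(NC(C)CCCNC(=O)Nc2ccc(Cl)cc2)c2ncccc2c1` is the next member. Relative to compound 2 the change is 4-chlorophenyl in place of ((4-hydroxyphenyl)carbamoyl)amino on an amide-type nitrogen. Among the compounds with values here, no measured step covers this exact change; the only measured step, from compound 1 to compound 2, shows that the 4-hydroxyphenyl end is weak, and compound 4 discards that end and becomes a plain aryl urea like compound 3. The expected step is an at least 16-fold lower number from compound 2 to compound 4 (1.22 log units; beyond the scatter), toward a lower number, beyond the scatter. Compound 4 is expected to give 6000 nM in this assay, estimated between 1500 nM and 30000 nM.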

Compound 4, half-maximal inhibitory concentration: 28000 nM
Compound 4: the middle estimate sits 4.7-fold (0.67 log units) below what was measured; the measured number falls inside the stated range.
By their numbers in this assay, from the lowest: compound 3; then compound 1; then compound 4. At a limit, above all of these: compound 2.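

Putting 4-chlorophenyl in place of ((4-hydroxyphenyl)carbamoyl)amino on the amide-type nitrogen gives an at least 3.5-fold lower number from compound 2 to compound 4 (0.55 log units; beyond the scatter), so in this assay the plain aryl urea restores a measurable number where the 4-hydroxyphenyl end gave none. That step is a bound and not a size, as the value of compound 2 is only a limit of the assay: the limit of > 100000 nM in this assay, at which 1 of the 4 values shown sits. Losing the longer end is not a gain in itself, however, as the same kind of replacement starting from the ((3-fluorophenyl)carbamoyl)amino end gives a 2.9-fold higher number from compound 1 to compound 4 (0.47 log units; beyond the scatter), which places the plain urea of compound 4 between the two longer-ended compounds and shows that the outcome at this position depends on which longer end is replaced.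

Still open, from the compounds shown here alone, is how far the linking unit and the aryl group act separately, as no aryl group appears here on both the longer end and the plain urea. Equally open, going by these compounds, is how the plain urea would read with an amine or a carboxylic acid on the phenyl ring in place of the chlorine.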